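Epimer of a limit-bound nucleoside: expected outcome

The source may report more compounds than this note shows. Statements on the series, on what has been measured and on what is new or still open speak of the compounds shown alone.

Going by the values given here, compound 1 `CSc1nc2cc(Cl)c(Cl)cc2n1[C@@H]1O[C@@H](CO)[C@@H](O)[C@H]1O` and compound 2 `CNc1nc2cc(Cl)c(Cl)cc2n1[C@@H]1O[C@H](CO)[C@@H](O)[C@H]1O` are the two measured members, and both reach the ceiling of a functional assay on KB cells (Homo sapiens) for inhibition; a higher number here means a weaker inhibitor, a lower number a stronger inhibitor. In this assay compound 1 gives > 100000 nM, a limit of the assay rather than a number. Compound 2 likewise returns only a limit, > 100000 nM. Both values therefore stand at the limit of > 100000 nM in this assay, at which 2 of the 2 values shown sit. Compound 3 `CNc1nc2cc(Cl)c(Cl)cc2n1[C@@H]1O[C@@H](CO)[C@@H](O)[C@H]1O` keeps every atom and bond of compound 2: the two compounds have the same atoms and bonds and differ only in configuration as drawn: 1 of 4 stereo elements differ; a stereocentre at a saturated ring carbon is drawn R in compound 2 and S in compound 3. Among the compounds with values here, no step between measured compounds exists, and with both anchors at the limit no size or direction beyond the scatter can be read. Compound 3 is expected to remain at the limit, estimated at 100000 nM with a range of 40000 nM to 300000 nM. The expected step is a number no higher from compound 2 to compound 3 (the limit leaves the size open), none beyond the scatter.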

Compound 3, half-maximal inhibitory concentration: > 100000 nM
Compound 3: a limit, no number (the forecaster's own chance of this, stated with the estimate: 85%); the middle value sits exactly at the limit.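

No step can be read between compound 3 and compound 1 or compound 2 in this assay, as each value is a limit, not a number: the limit of > 100000 nM in this assay, at which 3 of the 3 values shown sit.

The compounds shown leave open whether the drawn configuration or methylamino in place of methylsulfanyl affects inhibition.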